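The compounds below may be only part of what the source reports. "The series", "measured", "known", "first", "only" and "open" are said of these compounds alone.

Among the compounds with values here, compound 1 `COc1cc(/C=C/C(=O)c2cccc(-n3cc(-c4ccccc4)[nH]c3=O)c2)ccc1O` gives 3900 nM in a functional assay on EKVX cells (Homo sapiens) for inhibition (on this read-out lower numbers stand for stronger inhibition of growth and higher numbers for weaker inhibition of growth), the lowest of the two numbers measured so far; the nearest is compound 2 `O=C(/C=C/c1cccc(O)c1)c1cccc(-n2cc(-c3ccccc3)[nH]c2=O)c1`, which in this assay gives 15600 nM. Within the data shown here, the only measured step, a 4.0-fold higher number from compound 1 to compound 2 (0.60 log units; beyond the scatter), concerns the 3-hydroxyphenyl against the 4-hydroxy-3-methoxyphenyl end of the chain and leaves the phenyl on the shared core untouched.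

Compound 3 `COc1ccc(-c2cn(-c3cccc(C(=O)/C=C/c4ccc(O)c(OC)c4)c3)c(=O)[nH]2)cc1` differs from compound 1 in methoxy in place of hydrogen on an aromatic carbon. Among the measured compounds shown here, no measured step touches that phenyl, so nothing among the measured compounds bears directly on this change; the step from compound 1 to compound 2 speaks only for the other end of the molecule and gives no guide here. With the 4-hydroxy-3-methoxyphenyl end kept as in compound 1, the expectation for compound 3 is a number close to that of compound 1, with no step beyond the scatter in either direction, the estimated step being a 1.1-fold lower number from compound 1 to compound 3 (0.05 log units; within the scatter). For compound 3 the estimate in this assay is 3500 nM, with a range from 1400 nM to 9000 nM.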

Compound 3, concentration for 50% growth inhibition: 13400 nM
For compound 3 the middle estimate is 3.8-fold (0.58 log units) below the measured one; the whole stated range lies below it.
By their numbers in this assay, from the lowest: compound 1; then compounds 3 and 2 (each within the scatter of the next).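

In this assay the phenyl on the shared core proves not to be a silent place: with methoxy in place of hydrogen on an aromatic carbon, para to a large group, the result is a 3.4-fold higher number from compound 1 to compound 3 (0.54 log units; beyond the scatter), a step beyond the usual scatter. Within the data shown here, until now the only reading came from the other end of the molecule; each end now has one change away from compound 1 that gives a higher number, and compound 1 keeps the lowest value of the three, though this phenyl has so far been read with a single added group. No measurement of any property of these compounds accompanies the step, so it stands as an observation of growth inhibition alone.

The compounds shown leave open whether the higher number goes with methoxy in particular or with any group at this place, which a fluorine atom, a hydroxy group, an amine or a carboxylic acid on the same carbon would help to settle. They also leave open whether the methoxy step keeps its size when the 4-hydroxy-3-methoxyphenyl end is replaced by the 3-hydroxyphenyl end, since no pair shown tests the two changes separately on that background.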